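The compounds below may be only part of what the source reports. "The series", "measured", "known", "first", "only" and "open" are said of these compounds alone.

Working notes on the series. Compound 3 `O=C(Nc1cccc([N+](=O)[O-])c1)N[C@H]1CC[C@H](Oc2ccc(F)cc2)CC1` gives 6700 nM in a functional assay on CRL2813 cells (Homo sapiens) for cytotoxicity, read by sulforhodamine B assay, with a stated time of 5 days (on this read-out lower numbers stand for stronger inhibition and higher numbers for weaker inhibition), which is the lowest of the two numbers seen, though the gap to its nearest neighbour, compound 1 `O=C(Nc1ccccc1Br)N[C@H]1CC[C@H](Oc2ccc(F)cc2)CC1`, is within the scatter; compound 1 gives 7700 nM. Compound 2 `COc1ccccc1NC(=O)N[C@H]1CC[C@H](Oc2ccc(F)cc2)CC1` returns only a limit in this assay, > 20000 nM; this is the limit of > 20000 nM in this assay, at which 1 of the 3 values shown sits.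

The next compound, compound 4 `O=C(Nc1ccccc1I)N[C@H]1CC[C@H](Oc2ccc(F)cc2)CC1`, differs from compound 3 in one place: 2-iodophenyl in place of 3-nitrophenyl on an amide-type nitrogen. For the measured compounds named here, two measured steps bear on this. The step of a 1.1-fold lower number from compound 1 to compound 3 (0.06 log units; within the scatter) shows that moving from 2-bromophenyl to 3-nitrophenyl changed nothing beyond the scatter, while the step of an at least 2.9-fold lower number from compound 2 to compound 3 (0.47 log units; beyond the scatter) shows that 2-methoxyphenyl on the same nitrogen gave only a limit. Compound 4 carries 2-iodophenyl, which is nearer to the 2-bromophenyl of compound 1 than to the 2-methoxyphenyl of compound 2. The expected step of a 1.1-fold higher number from compound 3 to compound 4 (0.05 log units; within the scatter) is therefore no change beyond the scatter, or at most a slightly higher number. Compound 4 is estimated at 7500 nM in this assay, with a range from 3500 nM to 16000 nM.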

Compound 4, half-maximal inhibitory concentration: > 20000 nM
Compound 4 gave a limit, no number; the forecaster's own chance of this, stated with the estimate: 10%; middle value at least 2.6-fold (0.42 log units) from the limit.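

In this assay, 2-iodophenyl on this amide-type nitrogen does not behave like 2-bromophenyl: iodo in place of bromo on an aromatic carbon gives an at least 2.5-fold higher number from compound 1 to compound 4 (0.41 log units; beyond the scatter). The change from 3-nitrophenyl gives an at least 2.9-fold higher number from compound 3 to compound 4 (0.47 log units; beyond the scatter), so the equivalence of compound 1 and compound 3 does not extend to every aryl group here, and two halogens at this place are not interchangeable. The step between compound 2 and compound 4 cannot be read, and compound 4, like compound 2, is a limit and not a number: the limit of > 20000 nM in this assay, at which 2 of the 4 values shown sit.

Going by these compounds, the order of methoxy and iodo at this place stays open, as both compound 2 and compound 4 are limits. Also open, on these data alone, is whether 2-chlorophenyl or 3-aminophenyl on the same nitrogen would give a number near compound 1 and compound 3 or reach the limit.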